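The source may hold more compounds than are shown below. What is called first, only, known or untested is meant among the compounds shown, and "the series" means these compounds.

Measured so far:
Compound 1 `COCc1ccc(-c2ccc3nnc(C(N)=O)c(N[C@@H](C)c4nn(C)cc4C)c3c2)cn1` — 44 nM
Compound 2 `C[C@H](Nc1c(C(N)=O)nnc2ccc(-c3ccc(OCCCN(C)C)nc3)cc12)C1CCOCC1` — 1.9 nM
Compound 3 `C[C@H](Nc1c(C(N)=O)nnc2ccc(-c3ccc(OCCCN(C)C)nc3)cc12)c1ccn(C)n1` — 3.9 nM

All three were tested in an assay on HT-29 cells for inhibition of Serine-protein kinase ATM (Homo sapiens), read by fluorescence, with a stated time of 1 h; a lower number here means a stronger inhibitor, a higher number a weaker inhibitor. For the measured compounds named here, compound 3 holds the second-highest number of the three: compound 2 sits close below it, the only recorded step being a 2.1-fold higher number from compound 2 to compound 3 (0.31 log units; beyond the scatter), while compound 1 lies far above both. Compound 4 `Cc1cn(C)nc1[C@H](C)Nc1c(C(N)=O)nnc2ccc(-c3ccc(OCCCN(C)C)nc3)cc12` is not yet measured. It differs from compound 3 by methyl in place of hydrogen on an aromatic carbon. Going by the values given here, no measured pair isolates this change; compound 1 carries the same methyl-bearing group but also a different side group, so its number cannot be read as a test of the methyl alone. The expectation is therefore a step of about a 1.2-fold higher number from compound 3 to compound 4 (0.06 log units; within the scatter), within the scatter, giving compound 4 an estimated 4.5 nM with a likely range of 1.5 nM to 14 nM.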

Compound 4, half-maximal inhibitory concentration: 0.9 nM
Compound 4: middle estimate off by 5.0-fold (0.70 log units), on the high side; measured number outside the range, below it.
By their numbers in this assay, from the lowest: compound 4; then compound 2; then compound 3; then compound 1.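

Adding a single methyl to an aromatic carbon of the 1-methyl-1H-pyrazol-3-yl group gives a 4.3-fold lower number from compound 3 to compound 4 (0.64 log units; beyond the scatter) and so shows that this position responds to even one added carbon. The resulting 1,4-dimethyl-1H-pyrazol-3-yl group also outperforms oxan-4-yl, with a 2.1-fold lower number from compound 2 to compound 4 (0.32 log units; beyond the scatter). With that group held constant, 3-(dimethylamino)propoxy in place of methoxymethyl gives a 49-fold lower number from compound 1 to compound 4 (1.69 log units; beyond the scatter), the largest of these steps.

Nothing measured here explains these steps. As far as these compounds go, whether an ethyl group or a chlorine on the same aromatic carbon would match the methyl remains open.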